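A Fluorine Moved to a Different Carbon

The source may report more compounds than this note shows. Statements on the series, on what has been measured and on what is new or still open speak of the compounds shown alone.

Compound 1 `C=C1OC(=O)C=C1Cc1ccc(NC(=O)/C=C/c2ccc(F)cc2)cc1` and compound 2 `C=C1OC(=O)C=C1Cc1ccc(NC(=O)/C=C/c2ccccc2)cc1` share one core and differ only in a single fluoro on the outer ring. In a functional assay on MCF7 cells (Homo sapiens) for cytotoxicity, read by MTT assay, with a stated time of 48 h (on this read-out lower numbers stand for stronger inhibition and higher numbers for weaker inhibition), compound 1 gives 4430 nM, while compound 2 gives 9490 nM; the step of a 2.1-fold higher number from compound 1 to compound 2 (0.33 log units; beyond the scatter) runs beyond the scatter. For the measured compounds named here, compound 2 thus stands highest of the two numbers so far, with compound 1 its only neighbour.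

Compound 3 `C=C1OC(=O)C=C1Cc1ccc(NC(=O)/C=C/c2cccc(F)c2)cc1` is made from compound 2 by fluoro in place of hydrogen on an aromatic carbon. Going by the values given here, only one measured step bears on this: the removal of a fluoro from compound 1 to compound 2, which sits on the same ring but at a different carbon, raised the number modestly. Putting a fluoro back is therefore expected to lower the number modestly, with extra uncertainty because the carbon is not the same. Compound 3 is estimated at 6000 nM, within 3000 nM to 12000 nM, an expected step of a 1.6-fold lower number from compound 2 to compound 3 (0.20 log units; within the scatter).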

Compound 3, half-maximal inhibitory concentration: 39000 nM
Beside the measured number, compound 3's estimate is 6.5-fold (0.81 log units) below it, and the stated range ends below it.
By their numbers in this assay, from the lowest: compound 1; then compound 2; then compound 3.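

The fluoro does not act the same way at every carbon of this ring in this assay: adding it as 3-fluorophenyl gives a 4.1-fold higher number from compound 2 to compound 3 (0.61 log units; beyond the scatter), whereas removing it from 4-fluorophenyl gave a 2.1-fold higher number from compound 1 to compound 2 (0.33 log units; beyond the scatter), so the two placements fall on opposite sides of the unsubstituted phenyl. Changing only the fluoro's carbon, with 3-fluorophenyl in place of 4-fluorophenyl, gives an 8.8-fold higher number from compound 1 to compound 3 (0.94 log units; beyond the scatter), the widest gap among these three compounds, so in this set where the fluoro stands matters as much as whether it is present. Nothing available explains why the two carbons differ.

Going by these compounds, only hydrogen and fluoro have been seen on this ring, so it remains open whether a chlorine atom, a methoxy group or an amine on the same carbon would give a number closer to that of compound 3 or compound 1. On these data alone, it also remains open whether this order of the three compounds would hold in cells other than MCF7.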